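This account rests on a few compounds, and the source may have more. Where it says the series, first, only, none or still open, it means among the compounds named here.

In an ADME assay (liver) for metabolic stability, with Liver microsome (Rattus norvegicus) as the target, using microsomes and NADPH, with a stated time of 30 min, tested at 1 uM (a lower number here means slower removal, a higher number faster removal of the compound), compound 2 `Nc1ccc(S(=O)(=O)N2CCN(c3ncc(C(O)(C(F)(F)F)C(F)(F)F)cc3-c3ccc4sccc4c3)CC2)cn1` stands at the higher of the two measured numbers, 487 mL.min-1.g-1, while compound 1 `Nc1ccc(S(=O)(=O)N2CCN(c3ncc(C(O)(C(F)(F)F)C(F)(F)F)cc3-c3cnccc3F)CC2)cn1` gives 22 mL.min-1.g-1. Compound 3 `Nc1ccc(S(=O)(=O)N2CCN(c3ncc(C(O)(C(F)(F)F)C(F)(F)F)cc3-c3cc4ccccc4s3)CC2)cn1` differs from compound 2 in one place, on an aromatic carbon: 1-benzothiophen-2-yl in place of 1-benzothiophen-5-yl on an aromatic carbon. Going by the values given here, the only measured step that bears on this is a 22-fold higher number from compound 1 to compound 2 (1.35 log units; beyond the scatter), which brought in 1-benzothiophen-5-yl for 4-fluoropyridin-3-yl. Here one benzothiophenyl group replaces another with the same atoms, so no step beyond the scatter is expected in this assay. The expected change is a 1.2-fold lower number from compound 2 to compound 3 (0.09 log units; within the scatter). The estimate for compound 3 is 400 mL.min-1.g-1, with an expected range of 170 mL.min-1.g-1 to 800 mL.min-1.g-1.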

Compound 3, intrinsic clearance in microsomes: 315 mL.min-1.g-1
Beside the measured number, compound 3's estimate is 1.3-fold (0.10 log units) above it; low and high end bracket the measured number.
By their numbers in this assay, from the lowest: compound 1; then compounds 3 and 2 (each within the scatter of the next).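

In this assay, moving the attachment point from 1-benzothiophen-5-yl to 1-benzothiophen-2-yl gives a 1.5-fold lower number from compound 2 to compound 3 (0.19 log units; within the scatter), so at this position the two benzothiophenyl isomers are not told apart. The large step seen earlier recurs with the second isomer, as a 14-fold higher number from compound 1 to compound 3 (1.16 log units; beyond the scatter), and so is not confined to one attachment point. No measurement at hand gives a reason for either step. On these data alone, it remains open whether a plain phenyl ring or a pyridin-3-yl ring without the fluorine would fall with compound 1 or with compound 2 and compound 3.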